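Fluoro in place of hydroxy: expected loss of growth inhibition

The compounds below may be only part of what the source reports. "The series", "measured", "known", "first", "only" and "open" are said of these compounds alone.

In a functional assay on SW-620 cells (Homo sapiens) for inhibition (a higher number here means a weaker inhibitor of growth, a lower number a stronger inhibitor of growth), compound 1 `COc1ccc(-n2cnnc2-c2cc(OC)c(OC)c(OC)c2)cc1` gives 2750 nM and compound 2 `COc1ccc(-n2cnnc2-c2cc(OC)c(OC)c(OC)c2)cc1O` gives 380 nM. Compound 2 holds the lower of these two numbers, which makes it the stronger inhibitor of growth of the pair. The next compound is compound 3 `COc1ccc(-n2cnnc2-c2cc(OC)c(OC)c(OC)c2)cc1F`, not yet measured, with fluoro in place of hydroxy on an aromatic carbon. The site is ortho to a methoxy group and meta to a large group. Going by the values given here, only one measured step bears on this change: a 7.2-fold lower number from compound 1 to compound 2 (0.86 log units; beyond the scatter), with hydroxy in place of hydrogen on an aromatic carbon. Compound 3 lacks the hydroxy, as compound 1 does, so much of that step a 7.2-fold lower number from compound 1 to compound 2 (0.86 log units; beyond the scatter) is expected to be lost. Among the compounds with values here, no compound with fluoro has been measured, so the size of the loss remains uncertain. The expected step is a 3.7-fold higher number from compound 2 to compound 3 (0.57 log units; beyond the scatter), towards a higher number and beyond the scatter. In this assay the estimated value for compound 3 is 1400 nM, with an expected range of 450 nM to 4000 nM.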

Compound 3, concentration for 50% growth inhibition: 4070 nM
Compound 3: middle estimate off by 2.9-fold (0.46 log units), on the low side, and the stated range ends below it.
By their numbers in this assay, from the lowest: compound 2; then compounds 1 and 3 (each within the scatter of the next).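

In this assay the hydroxy at this site, ortho to a methoxy group and meta to a large group, does not tolerate replacement by fluoro: the result is an 11-fold higher number from compound 2 to compound 3 (1.03 log units; beyond the scatter) and this exceeds the earlier 7.2-fold lower number from compound 1 to compound 2 (0.86 log units; beyond the scatter) in size. Fluoro in place of hydrogen gives a 1.5-fold higher number from compound 1 to compound 3 (0.17 log units; within the scatter) so that fluoro and hydrogen cannot be told apart at this position, and of the three compounds only compound 2 stands apart from the others. No measurement at hand explains why hydroxy differs from fluoro and hydrogen here.

Still open, as far as these compounds go, is whether the lower number requires the hydroxy itself, or whether an amine, a hydroxymethyl group or a carboxylic acid at this site would give a comparable result. Also open, from the compounds shown here alone, is whether chloro or methyl would match fluoro and hydrogen, and whether a hydroxy on another carbon of the same ring would keep any of the difference between compound 1 and compound 2.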